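Shortening the Chain and Trading the Amide for a Hydroxamate

The source may report more compounds than this note shows. Statements on the series, on what has been measured and on what is new or still open speak of the compounds shown alone.

Compound 1 `CNC(=O)CCCCCCCn1nc(-c2ccc3oc(N)nc3c2)c2c(N)ncnc21` — 2250 nM
Compound 2 `Nc1ncnc2c1c(-c1cnc3[nH]ccc3c1)nn2CCCCCCC(=O)NO` — 19500 nM

Both compounds were tested in a functional assay on CNE-2 cells (Homo sapiens) for inhibition, read by MTT assay, with a stated time of 72 h; a lower number here means a stronger inhibitor, a higher number a weaker inhibitor. Compound 1 gives the lower of the two numbers, so it is the stronger inhibitor here; compound 2 sits far above it, a gap beyond the usual scatter. Among the compounds with values here, of compound 2 only its own number is known, and its core differs from that of compound 1, so it offers no measured step toward the change considered next.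

Compound 3 `Nc1nc2cc(-c3nn(CCCCC(=O)NO)c4ncnc(N)c34)ccc2o1` has not yet been measured. It differs from compound 1 by hydroxycarbamoyl in place of 3-(methylcarbamoyl)propyl on a saturated chain carbon, four bonds along the chain from an aromatic nitrogen. Within the data shown here, no measured pair shares this change, so the expectation rests on the two numbers alone. The step from compound 1 to compound 3 is expected to be a 2.7-fold higher number from compound 1 to compound 3 (0.43 log units; beyond the scatter), toward a weaker inhibitor and somewhat beyond the scatter. Compound 3 is estimated at 6000 nM, with a likely range from 1200 nM to 30000 nM.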

Compound 3, half-maximal inhibitory concentration: > 50000 nM
Compound 3: no number, only a limit; the forecaster's own chance of this, stated with the estimate: 10%; middle value at least 8.3-fold (0.92 log units) from the limit.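

Swapping 3-(methylcarbamoyl)propyl for hydroxycarbamoyl, on a saturated chain carbon four bonds along the chain from an aromatic nitrogen, gives an at least 22-fold higher number from compound 1 to compound 3 (1.34 log units; beyond the scatter) in this assay. Within the data shown here, this is the first measured step on the shared core, and it shows that activity in these cells depends strongly on what occupies this position, which compound 2, with its different core, could not show. The result for compound 3 is a limit of the assay and not a number, so the step gives only a minimum size: the limit of > 50000 nM in this assay, at which 1 of the 3 values shown sits.

The compounds shown leave open whether the loss follows from the shorter chain, from the new end group, or from both, since the two change together here. A longer chain ending in hydroxycarbamoyl, or a carboxylic acid at the chain end, on the core of compound 1 would help to separate these effects.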